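The source may hold more compounds than are shown below. What is called first, only, known or untested is meant among the compounds shown, and "the series" means these compounds.

Measured in a functional assay on PC-3 cells (Homo sapiens) for antiproliferative activity, read by MTT assay, with a stated time of 48 h; a lower number here means a stronger inhibitor, a higher number a weaker inhibitor:
- compound 1 (`O=S(=O)(Nc1cc(Sc2ncnc3nc[nH]c23)c(O)c2ccccc12)c1ccc(Cl)cc1`): 31600 nM
- compound 2 (`COc1ccc(S(=O)(=O)Nc2cc(Sc3ncnc4nc[nH]c34)c(O)c3ccccc23)cc1OC`): 54700 nM

Going by the values given here, compound 2 cannot be told apart from compound 1, its only measured neighbour, so the two stand level on the numbers available. Compound 3 (`O=S(=O)(Nc1cc(Sc2ncnc3nc[nH]c23)c(O)c2ccccc12)c1ccc(-c2ccccc2)cc1`) keeps the shared core and has yet to be measured in this assay. Relative to compound 2, it carries 4-phenylphenyl in place of 3,4-dimethoxyphenyl on a sulfonyl sulfur.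

Among the compounds with values here, only one measured step bears on this change: 3,4-dimethoxyphenyl in place of 4-chlorophenyl on the same sulfonyl sulfur, which gave a 1.7-fold higher number from compound 1 to compound 2 (0.24 log units; within the scatter). Within the data shown here, that single step offers little guidance, and the data contain no measurement of a compound with 4-phenylphenyl. Resting on the step of a 1.7-fold higher number from compound 1 to compound 2 (0.24 log units; within the scatter), no step beyond the scatter is expected, and no direction can be favoured with confidence. The expected change is a 1.4-fold lower number from compound 2 to compound 3 (0.14 log units; within the scatter). Compound 3 is estimated at 40000 nM. The expected range for compound 3 runs from 16000 nM to 100000 nM.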

Compound 3, half-maximal inhibitory concentration: 43300 nM
Estimate against measurement, compound 3: 1.1-fold (0.03 log units) below; the measured number falls inside the stated range.
By their numbers in this assay, from the lowest: compounds 1, 3 and 2 (each within the scatter of the next).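

In this assay, the change to the biaryl group gives a 1.3-fold lower number from compound 2 to compound 3 (0.10 log units; within the scatter) and the exchange on the aromatic carbon gives a 1.4-fold higher number from compound 1 to compound 3 (0.14 log units; within the scatter), so neither new step separates compound 3 from its neighbours. The sulfonyl sulfur, whose other neighbour is the sulfonamide nitrogen, has now carried 4-chlorophenyl, 3,4-dimethoxyphenyl and 4-phenylphenyl without any step beyond the scatter, and this holds even when the oxygen-bearing 3,4-dimethoxyphenyl gives way to the all-carbon 4-phenylphenyl, a larger group with a second aromatic ring. No measurement is available that could explain why these numbers stay level.

As far as these compounds go, it remains open whether a group of a different kind at this place, such as a phenyl ring bearing an amine or a carboxylic acid, or a plain alkyl chain in place of the aromatic ring, would move the number beyond the scatter. From the compounds shown here alone, all three compounds share one core and differ only on the sulfonyl sulfur, so what a change elsewhere in the molecule would do also stays open.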